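The source may hold more compounds than are shown below. What is called first, only, known or untested is meant among the compounds shown, and "the series" means these compounds.

The measured compounds:

Compound 1, `Cc1ccc2oc(-c3ccc(NC(=O)CN4CCN(CCCN(C)C)CC4)cc3)nc2c1`, gives 19100 nM in a functional assay on MCF7 cells (Homo sapiens) for cytotoxicity, read by MTT assay, with a stated time of 24 h; on this read-out higher numbers stand for weaker inhibition and lower numbers for stronger inhibition.
Compound 2, `Cc1cc(-c2nc3cc(Cl)ccc3o2)ccc1NC(=O)CCl`, gives only a limit in this assay, > 100000 nM.
Compound 3, `CN(C)CCCN1CCN(CC(=O)Nc2ccc(-c3nc4cc(Cl)ccc4o3)cc2)CC1`, gives 1650 nM in this assay.

Compound 3 and compound 1 share a core and differ in one place: methyl in place of chloro on an aromatic carbon. That change made a step of a 12-fold higher number from compound 3 to compound 1 (1.06 log units; beyond the scatter), so the number rose well beyond the usual scatter, meaning weaker inhibition for compound 1. Compound 2 carries a different core; how the core of compound 2 differs from that of compound 3 is not broken down here.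

Compound 4, `Cc1ccc2oc(-c3ccc(NC(=O)CCl)c(C)c3)nc2c1`, has not yet been measured in this assay. Among the measured compounds shown here, it differs from compound 2 by methyl in place of chloro on an aromatic carbon, which is the same change at the same place as the one from compound 3 to compound 1. Compound 2 stands at the limit of > 100000 nM in this assay, at which 1 of the 3 values shown sits. For the measured compounds named here, because compound 2 already sits at the limit of > 100000 nM in this assay, at which 1 of the 3 values shown sits, and the one measured example of this change raised the number, there is no reason to expect compound 4 to come down into the measurable range. The step that this expectation means, a step that the limit leaves unreadable from compound 2 to compound 4, cannot be read off a number and is an estimate only. Compound 4 is therefore expected to give about 200000 nM in this assay, with a range from 60000 nM to 1000000 nM, and most likely to be reported again as a limit rather than a number.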

Compound 4, half-maximal inhibitory concentration: 96500 nM
For compound 4 the middle estimate is 2.1-fold (0.32 log units) above the measured one; measured number inside the range.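

The swap of chloro for methyl on an aromatic carbon did not carry from one core to the other in this assay; the two results differ clearly: the same change on two cores in this assay, a 12-fold higher number (1.06 log units; beyond the scatter) from compound 3 to compound 1 and an at least 1.0-fold lower number (0.01 log units; that floor lies within the scatter) from compound 2 to compound 4, at least 11-fold (1.07 log units) apart, beyond the scatter of two such steps

Compound 2 gives > 100000 nM, which is a limit of the assay and not a number.

What can be written for this pair is an at least 1.0-fold lower number from compound 2 to compound 4 (0.01 log units; that floor lies within the scatter), and that is only a floor, so the true size of the step stays unknown, and two pairs alone show neither why the cores part ways nor what the swap would do on any third core.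

The compounds shown leave open how other groups would behave at the same place on either core, such as fluoro, bromo or methoxy in place of chloro. They also leave open which part of the core of compound 3 goes with the large step seen there, a question that a core with a morpholine or a simple dimethylamine in place of the piperazine chain could address.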